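This account rests on a few compounds, and the source may have more. Where it says the series, first, only, none or still open, it means among the compounds named here.

Compound 2, with the structure `C=C1C(=O)O[C@@H]2[C@@H]1[C@H](OC(=O)C(C)C)C(=O)[C@@H](C)C[C@H](O)C[C@](C)(O)[C@H]2OC(=O)C(C)C`, belongs to a pair of closely related esters on a shared core. In a functional assay on XF498 cells (Homo sapiens) for cytotoxicity, read by sulforhodamine B assay (on this read-out lower numbers stand for an effect already at smaller amounts and higher numbers for an effect only at larger amounts of compound), compound 2 gives 3.05 ug/mL, the higher of the two numbers measured. Among the compounds with values here, its only neighbour, compound 1 with the structure `C=C1C(=O)O[C@@H]2[C@@H]1[C@H](OC(=O)C(C)C)C(=O)[C@@H](C)C[C@H](O)C[C@](C)(O)[C@H]2OC(=O)/C(C)=C\C`, gives 1.31 ug/mL in this assay. Within the data shown here, the single measured step, a 2.3-fold higher number from compound 1 to compound 2 (0.37 log units; beyond the scatter), exchanges isopropyl for 1-methylprop-1-en-1-yl on a carbonyl carbon.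

Compound 3, with the structure `C=C1C(=O)O[C@@H]2[C@@H]1[C@H](OC(=O)C(C)CC)C(=O)[C@@H](C)C[C@H](O)C[C@](C)(O)[C@H]2OC(=O)C(C)C`, is not yet measured in this assay. It differs from compound 2 as follows: methyl in place of hydrogen on a saturated chain carbon, two bonds along the chain from a carbonyl carbon. Read one bond further out, the isopropylcarbonyl of compound 2 becomes a (sec-butyl)carbonyl in compound 3.

Among the measured compounds shown here, no measured step alters a saturated chain carbon in this way; the step from compound 1 to compound 2 concerns a different change on the carbonyl carbon, so it informs the question only loosely. Adding a single carbon on the ester chain is a small change. Compound 3 is therefore expected to lie close to compound 2 in this assay, with a step of a 1.0-fold lower number from compound 2 to compound 3 (0.01 log units; within the scatter) that probably stays within the scatter. The estimate for compound 3 is 3 ug/mL, with a range from 1.4 ug/mL to 6.5 ug/mL.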

Compound 3, concentration for half-maximal effect: 1.69 ug/mL
Beside the measured number, compound 3's estimate is 1.8-fold (0.25 log units) above it; measured number inside the range.
By their numbers in this assay, from the lowest: compounds 1, 3 and 2 (each within the scatter of the next, the first and the last beyond it).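

In this assay, the methyl in place of hydrogen on a saturated chain carbon, two bonds along the chain from a carbonyl carbon, turning the isopropylcarbonyl into a (sec-butyl)carbonyl, gives a 1.8-fold lower number from compound 2 to compound 3 (0.26 log units; within the scatter). Within the data shown here, this is the first reading at this position, and it shows that the added methyl leaves the two compounds indistinguishable here, unlike the only earlier step, a 2.3-fold higher number from compound 1 to compound 2 (0.37 log units; beyond the scatter), a different change on a carbonyl carbon that lies beyond the scatter. Nothing available bears on what lies behind this result.

Still open is how far this position stays as forgiving, since the compounds shown say nothing about a longer chain such as n-pentyl, or about an amine or a carboxylic acid on the same saturated chain carbon. On these data alone, it is also open whether the (sec-butyl)carbonyl would read the same alongside the 1-methylprop-1-en-1-yl ester of compound 1, which carries it in place of the isopropyl ester of compound 2.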